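This account rests on a few compounds, and the source may have more. Where it says the series, first, only, none or still open, it means among the compounds named here.

Compound 1 `COc1cc(/C=C/C(=O)c2cccc(NC(=O)c3ccco3)c2)ccc1O` stands highest of the three numbers here: in a functional assay on HUVEC cells (Homo sapiens) for inhibition, tested at 10 ug/mL (on this read-out higher numbers stand for a stronger effect at the one concentration tested and lower numbers for a weaker effect), compound 1 reaches 100%. Two other compounds keep the shared core and differ only in what sits on a carbonyl carbon. Compound 2 `COc1cc(/C=C/C(=O)c2cccc(NC(=O)c3ccccc3)c2)ccc1O` gives 69%, and compound 3 `CCOC(=O)C(=O)Nc1cccc(C(=O)/C=C/c2ccc(O)c(OC)c2)c1` gives 66%. Both replacements of the furan-2-yl were costly: a number 31 percentage points lower from compound 1 to compound 2 (beyond the scatter) and a number 34 percentage points lower from compound 1 to compound 3 (beyond the scatter), while a number 3 percentage points lower from compound 2 to compound 3 (within the scatter). Compound 4 `COc1cc(/C=C/C(=O)c2cccc(NC(C)=O)c2)ccc1O` changes the same carbonyl carbon in a third way: methyl in place of furan-2-yl on a carbonyl carbon. Because a number 31 percentage points lower from compound 1 to compound 2 (beyond the scatter) and a number 34 percentage points lower from compound 1 to compound 3 (beyond the scatter), a loss of similar size is expected for this third replacement as well. Compound 4 is therefore estimated at 65%, with a range from 45% to 85%, which would mean a number 35 percentage points lower from compound 1 to compound 4 (beyond the scatter).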

Compound 4, a percentage reported as inhibition, at one concentration (the size of the read-out at that concentration, not a potency): 32%
Compound 4: middle estimate off by 33 percentage points, on the high side; the whole stated range lies above it.
By their numbers in this assay, from the lowest: compound 4; then compounds 3 and 2 (each within the scatter of the next); then compound 1.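

The methyl of compound 4 shows that replacements on this carbonyl carbon do not all cost the same in this assay (a number 68 percentage points lower from compound 1 to compound 4 (beyond the scatter)). Methyl also falls well short of the other two replacements (a number 37 percentage points lower from compound 2 to compound 4 (beyond the scatter); a number 34 percentage points lower from compound 3 to compound 4 (beyond the scatter)), so the loss depends on which group enters. Nothing measured here explains why acetamido falls so far. The compounds shown leave open whether thiophen-2-yl, with sulfur in place of the furan oxygen, would hold the effect of furan-2-yl. They also leave open how a longer chain such as propyl would compare with methyl.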